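The compounds below may be only part of what the source reports. "The series", "measured", "known", "first", "only" and "open" are said of these compounds alone.

Measured in a functional assay on HeLa cells (Homo sapiens) for antiproliferative activity, read by CCK-8 assay, with a stated time of 72 h; on this read-out higher numbers stand for weaker inhibition and lower numbers for stronger inhibition:
- Compound 1 `Cc1cc(Nc2cc(N3CCN(C)CC3)nc(Nc3ccc(S(N)(=O)=O)cc3)n2)n[nH]1`: 3060 nM
- Compound 2 `Cc1cc(Nc2cc(N3CCN(C)CC3)nc(Nc3ccc([N+](=O)[O-])cc3)n2)n[nH]1`: 331 nM

Compound 2 has the lower of the two numbers, at 331 nM, and so inhibits more strongly. The next compound is compound 3 `COc1cccc(Nc2nc(Nc3cc(C)[nH]n3)cc(N3CCN(C)CC3)n2)c1`, which has 3-methoxyphenyl in place of 4-nitrophenyl on a nitrogen on an aromatic ring. For the measured compounds named here, only one measured step bears on this change: a 9.2-fold lower number from compound 1 to compound 2 (0.97 log units; beyond the scatter), where nitro replaced sulfamoyl on an aromatic carbon. Read backwards, that step shows a number rising when nitro is lost. Going by the values given here, no measured compound carries methoxy, so this is only a weak guide, and a rise of smaller size seems the fair expectation in this assay. The estimated change is a 2.4-fold higher number from compound 2 to compound 3 (0.38 log units; beyond the scatter). For compound 3 the expected value is 800 nM, with an estimated range from 200 nM to 3000 nM.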

Compound 3, half-maximal inhibitory concentration: 546 nM
Compound 3: the middle estimate sits 1.5-fold (0.17 log units) above what was measured, and the stated range covers the measured number.
By their numbers in this assay, from the lowest: compounds 2 and 3 (each within the scatter of the next); then compound 1.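

In this assay, putting 3-methoxyphenyl in place of 4-nitrophenyl on the nitrogen gives a 1.6-fold higher number from compound 2 to compound 3 (0.22 log units; within the scatter), so the two compounds cannot be told apart on this read-out. Putting the same 3-methoxyphenyl in place of 4-sulfamoylphenyl gives a 5.6-fold lower number from compound 1 to compound 3 (0.75 log units; beyond the scatter), which shows that the gain over compound 1 does not need a nitro group: a phenyl ring carrying methoxy instead stays within the scatter of compound 2. No measurement is available that explains these results.

The names 3-methoxyphenyl and 4-nitrophenyl differ in both the group and its number on the ring, so these compounds cannot separate the effect of one from the other. From the compounds shown here alone, it also remains open how this position would respond to an amine, a carboxylic acid or a longer chain such as ethoxy on the phenyl ring.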